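This account rests on a few compounds, and the source may have more. Where it says the series, first, only, none or still open, it means among the compounds named here.

Among the measured compounds shown here, in an ADME assay on microsomes from liver (Homo sapiens) for metabolic stability, with a stated time of 60 min, tested at 1 uM (on this read-out lower numbers stand for a less stable compound and higher numbers for a more stable compound), compound 1 `COc1cc(-c2cnn3cc(OC)c(C(C)C)nc23)ccn1` gives 40% and compound 2 `COc1cc(-c2cnn3cc(OC)c(C(C)(C)O)nc23)ccn1` gives 66%, which makes compound 2 the higher of the two numbers so far. For the measured compounds named here, the only measured step, a number 26 percentage points higher from compound 1 to compound 2 (beyond the scatter), is modest but beyond the usual scatter, and it accompanies hydroxy in place of hydrogen on a saturated chain carbon. The next structure is compound 3 `COc1cc(-c2cnn3cc(OC)c(C4CCOC4)nc23)ccn1`, and the change is oxolan-3-yl in place of 1-hydroxy-1-methylethyl on an aromatic carbon. Going by the values given here, that swap removes the hydroxy, while the ring has no measured example to guide it. Among the compounds with values here, the one guide is therefore the rise of a number 26 percentage points higher from compound 1 to compound 2 (beyond the scatter), and part of it is expected to be lost. The expected step is a number 16 percentage points lower from compound 2 to compound 3 (beyond the scatter), a modest fall with real uncertainty. In this assay, the estimate for compound 3 is 50%, within an expected range of 30% to 70%.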

Compound 3, percent of the compound remaining: 29%
Beside the measured number, compound 3's estimate is 21 percentage points above it; the whole stated range lies above it.
By their numbers in this assay, from the lowest: compound 3; then compound 1; then compound 2.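

At this position, on the aromatic carbon of the core, oxolan-3-yl does not keep the higher number seen with 1-hydroxy-1-methylethyl: in this assay the swap gives a number 37 percentage points lower from compound 2 to compound 3 (beyond the scatter), and measured against isopropyl it gives a number 11 percentage points lower from compound 1 to compound 3 (beyond the scatter). An oxygen in the group is therefore not enough on its own to go with a higher number, since 1-hydroxy-1-methylethyl and oxolan-3-yl each hold one oxygen and one hydrogen-bond acceptor, while only 1-hydroxy-1-methylethyl holds a hydrogen-bond donor. No measurement shown here explains the difference.

The compounds shown leave open whether the higher number follows the hydroxy itself or the branched open chain that carries it. A methoxy ether on the same branched chain, or a 1-amino-1-methylethyl group, at this position would help to separate the two.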